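The source may report more compounds than this note shows. Statements on the series, on what has been measured and on what is new or still open speak of the compounds shown alone.

Of the compounds shown here, three have so far been tested in an in vitro assay on BTI-TN-5B1-4 cells for inhibition of Amine oxidase [flavin-containing] A (Homo sapiens), read by Amplex Red, with a stated time of 15 min, tested at 100 uM; a lower number here means less inhibition, a higher number more inhibition at the concentration tested (going by the name of the read-out). Compound 1 `Fc1ccc(-c2csc(N/N=C\c3cccs3)n2)cc1` gives 40% in this assay. Compound 3 `Fc1ccc(-c2csc(N/N=C\c3cccnc3)n2)cc1` differs from compound 1 in a single spot: pyridin-3-yl in place of thiophen-2-yl on a carbon with a double bond to nitrogen. In this assay compound 3 gives 40%, so the step from compound 1 to compound 3 is no change at the digits printed from compound 1 to compound 3 (within the scatter). Compound 2 `C/C(=N/Nc1nc(-c2ccc(F)cc2)cs1)c1cccs1` gives 40% in this assay; how its core differs from the core of compound 1 is not broken down here, and its value sits level with those of compound 1 and compound 3.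

Compound 4 `C/C(=N/Nc1nc(-c2ccc(F)cc2)cs1)c1cccnc1` has not yet been measured. It differs from compound 2 by pyridin-3-yl in place of thiophen-2-yl on a carbon with a double bond to nitrogen. Within the data shown here, this is the same kind of change as the one from compound 1 to compound 3, though not the same: in compound 2 and compound 4 the carbon carrying the change also has a saturated chain carbon as a neighbour. Given that the earlier change produced no change at the digits printed from compound 1 to compound 3 (within the scatter), the expected step is no change at the digits printed from compound 2 to compound 4 (within the scatter). The estimate for compound 4 in this assay is 40%, with a likely range from 28% to 52%.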

Compound 4, a percentage reported as inhibition, at one concentration (the size of the read-out at that concentration, not a potency): 40%
Estimate against measurement, compound 4: no gap at the digits printed, and the stated range covers the measured number.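

In this assay, putting pyridin-3-yl in place of thiophen-2-yl on a carbon with a double bond to nitrogen gives no change at the digits printed from compound 2 to compound 4 (within the scatter), and this matches the result of the same change on the other core: the same change on two cores in this assay, no change at the digits printed (within the scatter) from compound 1 to compound 3 and no change at the digits printed (within the scatter) from compound 2 to compound 4, 0 percentage points apart, within the scatter of two such steps Across these two pairs, the swap therefore reads the same whether or not the carbon carrying it also has a saturated chain carbon as a neighbour. This does not establish a general rule for other cores, and each reading is the size of the inhibition at one concentration, so it does not show whether the effects of these compounds would also be level at other concentrations.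

The compounds shown have only thiophen-2-yl or pyridin-3-yl at this place, so it remains open whether a different group there, such as an amine, a carboxylic acid or a longer chain, would shift the reading beyond the scatter. As far as these compounds go, it also remains open whether the swap would read the same on a core unlike these two.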